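The source may report more compounds than this note shows. Statements on the series, on what has been measured and on what is new or still open speak of the compounds shown alone.

Measured compounds:
compound 1 `O=C(O)c1ccc(C#Cc2ccc3c(c2)C=C([N+](=O)[O-])C(C(F)(F)F)O3)cc1` with 1090 nM
compound 2 `CC(C)(C)C#Cc1ccc2c(c1)C=C([N+](=O)[O-])C(C(F)(F)F)O2` with 6590 nM

Going by the values given here, in a functional assay on 1321N1 cells for antagonist activity at P2Y purinoceptor 6 (Homo sapiens), read by fluorescence and calcium flux (a higher number here means a weaker inhibitor, a lower number a stronger inhibitor), compound 2 has the higher of the two numbers, and the step of a 6.0-fold higher number from compound 1 to compound 2 (0.78 log units; beyond the scatter) is the only measured step. Compound 3 `O=[N+]([O-])C1=Cc2cc(Br)ccc2OC1C(F)(F)F` differs from compound 2 by bromo in place of 3,3-dimethylbut-1-yn-1-yl on an aromatic carbon. Among the compounds with values here, no measured step bears directly on exchanging the alkynyl group for a halogen, so the expectation rests only on compound 2 standing weakest. Compound 3 is therefore expected to give a similar or somewhat higher number, a step of a 1.5-fold higher number from compound 2 to compound 3 (0.18 log units; within the scatter), with an estimate of 10000 nM and a range from 3000 nM to 40000 nM.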

Compound 3, half-maximal inhibitory concentration: 3490 nM
Beside the measured number, compound 3's estimate is 2.9-fold (0.46 log units) above it; measured number inside the range.
By their numbers in this assay, from the lowest: compound 1; then compounds 3 and 2 (each within the scatter of the next).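

In this assay the step of a 1.9-fold lower number from compound 2 to compound 3 (0.28 log units; within the scatter) shows that the 3,3-dimethylbut-1-yn-1-yl group on this aromatic carbon can give way to a lone bromo without a change beyond the scatter. At this position, then, neither the triple bond nor the six carbons are needed to keep the number at this level. Nothing available explains this result. The compounds shown leave open how an amine, a chloro or a methoxy group would read on this carbon.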